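A few compounds are considered here, and "the series" means these few. Any claim that something is new, unique, unknown or untested is made for them only; others in the source may bear on it.

Compound 1 `CCCCc1ccc(CNC(=O)N(C)C)c(=O)n1Cc1ccc(-c2ccccc2-c2nn[nH]n2)cc1`: 28%
Compound 2 `CCCCc1ccc(CNS(C)(=O)=O)c(=O)n1Cc1ccc(-c2ccccc2-c2nn[nH]n2)cc1`: 54.8%
Compound 3 `CCCCc1ccc(CNC(=O)Nc2ccccc2)c(=O)n1Cc1ccc(-c2ccccc2-c2nn[nH]n2)cc1`: 0%

In a functional assay on the whole organism (artery) for inhibition, with Rattus norvegicus as the target, at a dose of 3 mg/kg by the intraduodenal route (on this read-out higher numbers stand for more inhibition at the one dose given (going by the name of the read-out) and lower numbers for less inhibition), compound 2 gives 54.8%, the highest of the three numbers; the step of a number 26.8 percentage points higher from compound 1 to compound 2 (beyond the scatter) and the step of a number 54.8 percentage points lower from compound 2 to compound 3 (beyond the scatter) both set it apart from its neighbours beyond the scatter. All three share one core and differ only in the group carried on the saturated chain carbon bound to an aromatic carbon.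

Compound 4 `CCCCc1ccc(CN(Cc2ccccc2)C(C)=O)c(=O)n1Cc1ccc(-c2ccccc2-c2nn[nH]n2)cc1` changes that same group: acetyl(benzyl)amino in place of methanesulfonamido on a saturated chain carbon bound to an aromatic carbon. Going by the values given here, two measured steps bear on this. The step of a number 26.8 percentage points higher from compound 1 to compound 2 (beyond the scatter) shows that a methylsulfonyl on the amine nitrogen scored higher than a carbonyl-bearing dimethylcarbamoyl, and the step of a number 54.8 percentage points lower from compound 2 to compound 3 (beyond the scatter) shows that adding a phenyl ring in place of methylsulfonyl brought the read-out to nothing. Compound 4 gives up the methylsulfonyl for a carbonyl-bearing acetyl and at the same time brings in a benzyl ring, so both precedents point downward. A large drop in this assay is therefore expected, a number 44.8 percentage points lower from compound 2 to compound 4 (beyond the scatter). Compound 4 is estimated to give 10%, within a range of 0% to 30%.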

Compound 4, a percentage reported as inhibition, in the whole organism at one dose (the size of the read-out at that dose, not a potency): 76.3%
Beside the measured number, compound 4's estimate is 66.3 percentage points below it, and the stated range ends below it.
By their numbers in this assay, from the lowest: compound 3; then compound 1; then compound 2; then compound 4.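

In this assay, the step of a number 21.5 percentage points higher from compound 2 to compound 4 (beyond the scatter) shows that this position does not depend on the methanesulfonamido group, since acetyl(benzyl)amino, with no hydrogen-bond donor and a larger count of heavy atoms, makes compound 4 the highest of the four. An aromatic ring at this place therefore does not by itself remove the read-out, as the step of a number 76.3 percentage points higher from compound 3 to compound 4 (beyond the scatter) separates two groups that each carry such a ring, and a carbonyl-bearing group is not necessarily the poorer choice either, as the step of a number 48.3 percentage points higher from compound 1 to compound 4 (beyond the scatter) shows. No measurement available here explains why these groups differ, so the pattern stands as an observation only.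

As far as these compounds go, the change swaps the acetyl for the sulfonyl and adds the benzyl in one move, so it remains open how much of the gain belongs to each part; a plain acetylamino group and a benzylamino group would separate the two. Also open, from the compounds shown here alone, is whether a longer chain or a cyclohexylmethyl group could stand in for the benzyl on that nitrogen, and whether the order seen at this one dose would hold at other doses.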